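Swapping Fluoro for Bromo in a Small Compound Series

The source may hold more compounds than are shown below. What is called first, only, known or untested is meant among the compounds shown, and "the series" means these compounds.

Three related compounds have been measured so far. In a functional assay on L1210 cells (Mus musculus) for inhibition (on this read-out higher numbers stand for weaker inhibition and lower numbers for stronger inhibition), compound 2 `O=C1/C(=C/c2ccc(F)cc2)CCCc2ccccc21` gives 60300 nM as its result. Compound 3 `O=C1/C(=C/c2cccc(Br)c2)CCCc2ccccc21` gives 51000 nM and lies within the usual scatter of compound 2, so the two cannot be told apart. Compound 1 `CN(C)c1ccc(/C=C2\CCc3ccccc3C2=O)cc1` gives 17500 nM in the same test, a clearly lower number that is beyond the scatter from compound 2, although it differs from compound 2 in more than one place. Compound 2 therefore belongs with compound 3 in the high-number, weaker-inhibition part of this small set.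

Next comes compound 4 `O=C1/C(=C/c2ccc(Br)cc2)CCCc2ccccc21`, which has not yet been measured. Its change from compound 2 is a single swap, bromo in place of fluoro on an aromatic carbon is the full count. Among the measured compounds shown here, no measured pair shows this swap directly. The closest hint is compound 3, which also carries bromo on an aromatic carbon and gives 51000 nM as its result. The expected step, a 1.2-fold lower number from compound 2 to compound 4 (0.08 log units; within the scatter), is a slight drop in the number that stays within the scatter. For compound 4 the estimate is 50000 nM with an expected range from 22000 nM to 100000 nM in this test.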

Compound 4, half-maximal inhibitory concentration: 50900 nM
For compound 4 the middle estimate is 1.0-fold (0.01 log units) below the measured one; measured number inside the range.
By their numbers in this assay, from the lowest: compound 1; then compounds 4, 3 and 2 (each within the scatter of the next).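

Bromo in place of fluoro on an aromatic carbon, para to a large group, now has a direct reading in this assay, with a 1.2-fold lower number from compound 2 to compound 4 (0.07 log units; within the scatter) as its step. Before this, no measured pair differed by this single swap, and the only hint came from a compound with its bromo placed elsewhere on the ring; now the swap itself can be seen to leave the result indistinguishable in this test, and both compounds stay in the weaker-inhibition part of this small set. No independent measurement on these compounds bears on this result, so it stands as a plain observation with no explanation attached.

Still open, going by these compounds, is whether a group of a different kind at this same position, such as a methoxy group, a primary amine or a carboxylic acid, would move the number beyond the scatter, since two halogens alone say little about the range of groups this position can accept. Compound 1 gives a lower number, 17500 nM in this assay, but it differs from these compounds in more than one place, so that number cannot be credited to any single group.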